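The compounds below may be only part of what the source reports. "The series", "measured", "known", "first", "only" and "open" are said of these compounds alone.

Measured so far in a functional assay on the whole organism with Mus musculus as the target, with a stated time of 90 min, at a dose of 25 umol/kg by the oral route; a higher number here means a stronger effect of the compound at the dose given, a lower number a weaker effect:
Compound 1, `O=C(O)CN(c1nc(Cl)nc2c1ncn2C1CCCCO1)C1CC1` — compound 1 gives 8.22%
Compound 2, `N=C(N)NCCC[C@H](NC(=O)CN(c1nc(Cl)nc2c1ncn2C1CCCCO1)C1CC1)C(=O)OCc1ccccc1` — compound 2 gives 61.6%

Compound 2 holds the highest of the two numbers. Its nearest neighbour is compound 1, and the gap between the two values is beyond the scatter of this assay. Among the compounds with values here, no single-point step between two measured compounds is available for this series, so there is no measured step against which the change below can be set.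

Compound 3, `O=C(CN(c1nc(Cl)nc2c1ncn2C1CCCCO1)C1CC1)N[C@@H](CCC(=O)OCc1ccccc1)C(=O)OCc1ccccc1`, is not yet measured. It differs from compound 2 as follows: a group of 10 heavy atoms (8 carbon, 2 oxygen; one six-membered aromatic ring of carbon only) in place of a group of 5 heavy atoms (2 carbon, 3 nitrogen; no ring), on a saturated chain carbon, three bonds along the chain from an amide-type nitrogen and a carbonyl carbon. The entering benzyloxycarbonyl carries a six-membered aromatic ring of carbon only, where the leaving group, which has no common name, carries no ring.

Within the data shown here, with no measured step of this kind to rest on, the expectation for compound 3 is a downward step from compound 2, a number 23.6 percentage points lower from compound 2 to compound 3 (beyond the scatter), likely beyond the scatter, though with wide uncertainty. Compound 3 is expected to give 38% in this assay, with a range from 8% to 70%.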

Compound 3, a percentage reported as activity, at one dose (the size of the read-out at that dose, not a potency): 25.2%
Beside the measured number, compound 3's estimate is 12.8 percentage points above it; the range from low to high includes it.
By their numbers in this assay, from the lowest: compound 1; then compound 3; then compound 2.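

In this assay, within the data shown here, the step of a number 36.4 percentage points lower from compound 2 to compound 3 (beyond the scatter) is the first measured at this place, on a saturated chain carbon, three bonds along the chain from an amide-type nitrogen and a carbonyl carbon, and it is large. It shows that the read-out at this dose is sensitive to the group at this place: benzyloxycarbonyl, with its six-membered aromatic ring of carbon only and no hydrogen-bond donors, does not hold the level seen with the group of 5 heavy atoms (2 carbon, 3 nitrogen) that it replaces, although one pair at one dose sets no trend. Nothing measured on these compounds bears on why the number moves as it does.

The single change swaps the ring and the nitrogen-bearing group together, so the compounds shown leave open which of the two accounts for the step. A primary amine or a carboxylic acid at this place, or a longer chain ending in the same group of 5 heavy atoms, would be the comparisons that could begin to separate them.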